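Sulfone replaces tetrazole on the chain of compound 3

The source may report more compounds than this note shows. Statements on the series, on what has been measured and on what is new or still open speak of the compounds shown alone.

Compound 1, `CCc1cc(C(C)=O)c(O)cc1OCCCCC#N`: 57%
Compound 2, `CCc1cc(C(C)=O)c(O)cc1OCCCCCC(C)(C)C(=O)O`: 73%
Compound 3, `CCc1cc(C(C)=O)c(O)cc1OCCCCCC(C)(C)c1nnnn1C`: 59%

In an assay on isolated protein for binding affinity to leukotriene B4 receptor 1 (Homo sapiens), tested at 1 uM (on this read-out higher numbers stand for more inhibition at the one concentration tested (going by the name of the read-out) and lower numbers for less inhibition), compound 3 stands second highest of the three, close to compound 1 within the scatter and below compound 2 by a modest margin. Compound 4, `CCc1cc(C(C)=O)c(O)cc1OCCCCCCS(C)(=O)=O`, carries the change ((methylsulfonyl)methyl in place of 1-methyl-1-(1-methyl-1H-tetrazol-5-yl)ethyl on a saturated chain carbon, five bonds along the chain from an oxygen on an aromatic ring). Among the measured compounds shown here, two steps bear on this end of the chain: a number 16 percentage points higher from compound 1 to compound 2 (beyond the scatter) and a number 14 percentage points lower from compound 2 to compound 3 (beyond the scatter). Both were modest, and only compound 2 with its carboxy group stands apart. Since the new group is neither the carboxy of compound 2 nor the tetrazole of compound 3, compound 4 is expected to stay near compound 3, with a number 4 percentage points lower from compound 3 to compound 4 (within the scatter) within the scatter. Compound 4 is estimated at 55%, in the range 35% to 72%.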

Compound 4, a percentage reported as inhibition, at one concentration (the size of the read-out at that concentration, not a potency): 62%
Compound 4: middle estimate off by 7 percentage points, on the low side, within the range that was stated.
By their numbers in this assay, from the lowest: compounds 1, 3 and 4 (each within the scatter of the next); then compound 2.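

Putting (methylsulfonyl)methyl, a group with no ring, in place of 1-methyl-1-(1-methyl-1H-tetrazol-5-yl)ethyl gives a number 3 percentage points higher from compound 3 to compound 4 (within the scatter) and so does not shift the read-out, which shows that a tetrazole ring is not needed at this position for this level of inhibition. The comparison with the nitrile reads the same, with a number 5 percentage points higher from compound 1 to compound 4 (within the scatter) and no separation, whereas a number 11 percentage points lower from compound 2 to compound 4 (beyond the scatter) shows that the sulfone does not match the carboxy end.

Whether an amine or a primary amide at this chain end, or a longer chain carrying the sulfone, would reach the level of the carboxy group stays open, and nothing shown here gives a reason for these differences.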